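The source may report more compounds than this note shows. Statements on the series, on what has been measured and on what is new or still open speak of the compounds shown alone.

Measured in a functional assay on MCF7 cells (Homo sapiens) for antiproliferative activity, read by CCK-8 assay, with a stated time of 24 h; a lower number here means a stronger inhibitor, a higher number a weaker inhibitor:
- Compound 1 `CCN(CC)Cc1ccc2nc(NC(=O)N/N=C/c3ccccn3)sc2c1`: > 40000 nM, a limit
- Compound 2 `CCN(CC)Cc1ccc2nc(NC(=O)N/N=C(\C)c3ccccn3)sc2c1`: > 40000 nM, a limit

Compound 2 gives no number in this assay, only the limit > 40000 nM. Among the measured compounds shown here, the same holds for compound 1, so the series so far is described by the limit of > 40000 nM in this assay, at which 2 of the 2 values shown sit.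

Compound 3 `CCN(CC)Cc1ccc2nc(NC(=O)N/N=C(\C)c3cnccn3)sc2c1` carries pyrazin-2-yl in place of pyridin-2-yl on a carbon with a double bond to nitrogen, and the counted difference is pyrazin-2-yl in place of pyridin-2-yl on a carbon with a double bond to nitrogen. For the measured compounds named here, the only measured step is a step that the two limits leave unreadable from compound 1 to compound 2. That step has no readable size and involves no pyrazin-2-yl group, so it offers nothing to carry over to this exchange.

No step beyond the scatter can therefore be expected in either direction in this assay, and another limit is the most likely report. The expectation rests on compound 2, whose > 40000 nM is a limit. The estimated step is a number no higher from compound 2 to compound 3 (the limit leaves the size open). The estimate for compound 3 is 40000 nM, with an expected range of 15000 nM to 80000 nM.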

Compound 3, half-maximal inhibitory concentration: > 40000 nM
Compound 3 was reported as a limit; the forecaster's own chance of this, stated with the estimate: 80%; the middle value lies on the limit itself.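

No new step can be read among compound 1, compound 2 and compound 3 in this assay because each result is only a limit: the limit of > 40000 nM in this assay, at which 3 of the 3 values shown sit.

The compounds shown leave open what inhibitory concentration any of the three actually has, and whether pyrazin-2-yl in place of pyridin-2-yl makes any difference in this series.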